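The source may hold more compounds than are shown below. What is called first, only, known or untested is meant among the compounds shown, and "the series" means these compounds.

Measured in a functional assay on the whole organism with Mus musculus as the target, in the rotarod test; a lower number here means that less compound is needed, a higher number that more compound is needed for the effect:
- compound 1 `C/C(=C\C(=O)NC1CC1)c1cccc(F)c1`: 71 mg/kg
- compound 2 `NC(=O)/C=C1\CCc2cc(F)c(F)cc21`: 82 mg/kg
- compound 3 `NC(=O)/C=C1\CCc2ccc(Cl)cc21`: 221 mg/kg

Compound 3 carries the highest number of the three in this assay, and its gaps to compound 2 and to compound 1 both lie beyond the scatter. Compound 1 and compound 2 sit level with each other within the scatter.

The next compound is compound 4 `NC(=O)/C=C1\CCc2ccccc21`, which differs from compound 3 in one place: hydrogen in place of chloro on an aromatic carbon. Among the measured compounds shown here, no measured pair isolates this change, so its size has no direct precedent. For the measured compounds named here, the only guide is indirect: the closest measured relative of compound 3 is compound 2, which gives 82 mg/kg and so shows that this shared core can sit well under compound 3. A modest move toward a lower number is therefore expected, though it may well stay within the scatter. The expected change is a 1.6-fold lower number from compound 3 to compound 4 (0.20 log units; within the scatter) in this estimate. The estimate for compound 4 is 140 mg/kg as the expected value. The range expected for compound 4 runs from 65 mg/kg to 300 mg/kg as estimated here.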

Compound 4, dose for half-maximal effect: 164 mg/kg
Compound 4: the middle estimate sits 1.2-fold (0.07 log units) below what was measured; the range from low to high includes it.
By their numbers in this assay, from the lowest: compounds 1, 2, 4 and 3 (each within the scatter of the next, the first and the last beyond it).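

In this assay, among the compounds shown here, hydrogen in place of chloro on this aromatic carbon amounts to a 1.3-fold lower number from compound 3 to compound 4 (0.13 log units; within the scatter), and this is the first step that isolates a single change. The place, meta to a fused ring and para to a fused ring, therefore loses its chloro with no change beyond the scatter, so on this core the chloro is not required to keep the number at this level, and the unsubstituted form reads level with the chlorinated one. No measured property or other supporting data bears on this step, and what lies behind its small size cannot be said from the values alone.

Still open, going by these compounds, is whether any group on this aromatic carbon moves the number beyond the scatter, for example methoxy, an amine or a carboxylic acid, since a single pair with chloro and hydrogen spans only a narrow choice of groups. Also open, on these data alone, is how the amide of this core responds to a single change there, such as a longer chain on the amide nitrogen, which would show whether that end of the molecule is as forgiving as this aromatic carbon.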